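The source may hold more compounds than are shown below. What is called first, only, known or untested is meant among the compounds shown, and "the series" means these compounds.

Working notes on the series.

Compound 1 `CC(C)(C)OC(=O)N1CCN(c2cccc3c2cnn3-c2ccccc2F)C1=O` stands highest of the three numbers in an ADME assay on the whole organism (strain Sprague-Dawley) for pharmacokinetics, with Rattus norvegicus as the target, read by LC-MS (a higher number here means that a larger share of the oral dose reaches the circulation, a lower number that a smaller share of the oral dose reaches the circulation), where compound 1 gives 100%. Compound 3 `O=c1[nH]ccn1CCOc1nn(-c2ccccc2F)c2ccc(F)cc12` is nearest, and in this assay compound 3 gives 35%; compound 2 `Fc1ccc2c(c1)c(OCCn1ccnc1)nn2-c1ccccc1F` is furthest, and in this assay compound 2 gives 28%. Both gaps to compound 1 are beyond the scatter.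

Compound 4 `O=C1N(Cc2ncco2)CCN1c1cccc2c1cnn2-c1ccccc1F` is not yet measured in this assay. It differs from compound 1 in one place: (1,3-oxazol-2-yl)methyl in place of tert-butoxycarbonyl on an amide-type nitrogen in a ring.

Among the measured compounds shown here, the only measured step, a number 7 percentage points higher from compound 2 to compound 3 (within the scatter), sits on a saturated chain carbon of a different core and does not touch the ring nitrogen that changes here, so no measured step bears on the change from compound 1 to compound 4. Compound 1 already reaches the top of the scale, so a step can only hold or fall. Absent a comparable step, compound 4 is expected to come out below compound 1, with a step of a number 40 percentage points lower from compound 1 to compound 4 (beyond the scatter). The estimate for compound 4 in this assay is 60%, within a range from 25% to 100%.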

Compound 4, oral bioavailability: 37%
Estimate against measurement, compound 4: 23 percentage points above; measured number inside the range.
By their numbers in this assay, from the lowest: compounds 2, 3 and 4 (each within the scatter of the next); then compound 1.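

In this assay, the one step shown on the amide-type nitrogen in the ring is large, a number 63 percentage points lower from compound 1 to compound 4 (beyond the scatter), which shows that this position is not indifferent: with the rest of the structure unchanged, the group on that nitrogen alone carries a shift beyond the scatter. The counts of hydrogen-bond donors and acceptors and the net charge are the same for tert-butoxycarbonyl and (1,3-oxazol-2-yl)methyl, and these counts therefore do not separate the two groups, although the measured numbers do. No measurement at hand accounts for this step.

Still open, from the compounds shown here alone, is whether the high number is particular to tert-butoxycarbonyl or is shared by other carbamates such as ethoxycarbonyl. Also open, going by these compounds, is how a plain methyl, a longer alkyl chain or an aminoethyl chain on this nitrogen would read.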